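A few compounds are considered here, and "the series" means these few. Any claim that something is new, unique, unknown or untested is made for them only; others in the source may bear on it.

Compound 2 `Fc1ccc(CNc2nc(Nc3cc(C4CC4)[nH]n3)c3ccccc3n2)cc1` gives 40 nM in an assay for inhibition of high affinity nerve growth factor receptor (Homo sapiens), read by HTRF, with a stated time of 30 min, in the presence of a further agent that is not named here; on this read-out lower numbers stand for stronger inhibition and higher numbers for weaker inhibition. Compound 1 `Cc1cc(Nc2nc(NCc3ccc(F)cc3)nc3ccccc23)n[nH]1` gives 20 nM in this assay, and the step of a 2.0-fold higher number from compound 1 to compound 2 (0.30 log units; within the scatter) lies within the scatter, so the two numbers are not distinguishable. Compound 3 `CCc1cc(Nc2nc(NCc3ccc(F)cc3)nc3ccccc23)n[nH]1` differs from compound 2 by ethyl in place of cyclopropyl on an aromatic carbon. Going by the values given here, the only measured step bearing on this change is a 2.0-fold higher number from compound 1 to compound 2 (0.30 log units; within the scatter), which stayed within the scatter, so no step beyond the scatter is expected here either. Compound 3 is therefore expected to give about 30 nM, within a range of 15 nM to 60 nM. The expected step is a 1.3-fold lower number from compound 2 to compound 3 (0.12 log units; within the scatter).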

Compound 3, half-maximal inhibitory concentration: 53 nM
Estimate against measurement, compound 3: 1.8-fold (0.25 log units) below; low and high end bracket the measured number.
By their numbers in this assay, from the lowest: compounds 1, 2 and 3 (each within the scatter of the next, the first and the last beyond it).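

In this assay, ethyl and cyclopropyl on this aromatic carbon cannot be told apart (a 1.3-fold higher number from compound 2 to compound 3 (0.12 log units; within the scatter)). Going from methyl to ethyl, however, gives the first step at this position beyond the scatter, though a modest one (a 2.7-fold higher number from compound 1 to compound 3 (0.42 log units; beyond the scatter)), so the position is not wholly indifferent to the group it carries, even though compound 2 stays within the scatter of both. No measurement shown here accounts for this. The compounds shown leave open whether a longer chain such as propyl, or an amine, would be tolerated on this carbon.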